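A Changed Group on a Compound at the Assay Limit

The source may hold more compounds than are shown below. What is called first, only, known or untested is meant among the compounds shown, and "the series" means these compounds.

This piece follows one structural change in a series tested in a functional assay on HL-60 cells (Homo sapiens) for inhibition, read by CCK-8 assay, with a stated time of 48 h; on this read-out lower numbers stand for stronger inhibition and higher numbers for weaker inhibition. Compound 1 `COc1ccc(Oc2ccccc2-c2ccsc2S(=O)(=O)N2CCN(C(=S)Nc3ccc([N+](=O)[O-])cc3)CC2)cc1OC` gives > 50000 nM, which is a limit and not a number. Compound 2 `COc1ccc(Oc2ccc([N+](=O)[O-])cc2-c2ccsc2S(=O)(=O)N2CCN(C(=S)Nc3ccc([N+](=O)[O-])cc3)CC2)cc1OC` gives > 50000 nM, also a limit. Compound 3 `O=S(=O)(NCCNC(=S)Nc1cc(C(F)(F)F)cc(C(F)(F)F)c1)c1ccc(-c2ccccc2OCc2ccccc2)s1`, a differently built molecule, gives a true number of 2100 nM. Going by these compounds, compound 1 therefore stands at the edge of what this assay can read, and its real value remains unknown.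

Compound 4 `COc1ccc(Oc2ccccc2-c2ccsc2S(=O)(=O)N2CCN(C(=O)Nc3cccc([N+](=O)[O-])c3)CC2)cc1OC` keeps the core of compound 1 and changes in one place: a group of 12 heavy atoms (7 carbon, 2 nitrogen, 3 oxygen; one six-membered aromatic ring of carbon only) in place of a group of 12 heavy atoms (7 carbon, 2 nitrogen, 2 oxygen, 1 sulfur; one six-membered aromatic ring of carbon only), on an amine nitrogen in a ring. The entering group, (3-nitrophenyl)carbamoyl, sits on an amine nitrogen in a ring.

Within the data shown here, only one measured step exists. Placing a nitro in place of hydrogen on an aromatic carbon gives a step that the two limits leave unreadable from compound 1 to compound 2. That step lies elsewhere on the molecule and has no readable size, so it offers little guidance. The wider picture is the limit of > 50000 nM in this assay, at which 2 of the 3 values shown sit.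

Among the measured compounds shown here, with no measured step at this place, the expectation stays close to the limit. The expected change is an at least 1.2-fold lower number from compound 1 to compound 4 (0.09 log units; that floor lies within the scatter), a modest estimated move towards stronger inhibition at most, and it may not be readable at all. Compound 4 is estimated at 40000 nM, with an expected range from 10000 nM to 50000 nM.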

Compound 4, half-maximal inhibitory concentration: > 50000 nM
Compound 4: only a limit was reported; the forecaster's own chance of this, stated with the estimate: 60%; middle value at least 1.2-fold (0.09 log units) from the limit.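

Compound 4 gives > 50000 nM in this assay, which is a limit and not a number. Compound 1 also stands at a limit, so the step between compound 1 and compound 4 cannot be read. The compounds shown leave open how far, if at all, the (3-nitrophenyl)carbamoyl group shifts inhibition, with most values resting at one limit: the limit of > 50000 nM in this assay, at which 3 of the 4 values shown sit.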